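The source may hold more compounds than are shown below. What is called first, only, known or untested is meant among the compounds shown, and "the series" means these compounds.

Measured so far in an assay on HEK293 cells for binding affinity to prostaglandin E2 receptor EP2 subtype (Homo sapiens); a lower number here means a stronger inhibitor, a higher number a weaker inhibitor:
Compound 1 `O=C(O)CCc1ccccc1-c1cc(-c2ccccc2OCc2ccccc2)cs1`: compound 1 gives 2900 nM
Compound 2 `O=C(O)/C=C/c1ccccc1-c1ccc(Cl)c(Cl)c1`: compound 2 gives 7500 nM
Compound 3 `O=C(O)/C=C/c1ccccc1-c1cccc(-c2ccccc2OCc2ccccc2)c1`: compound 3 gives 830 nM

Among these three, compound 3 has the lowest number, and its gaps to compound 1 and to compound 2 both lie beyond the usual scatter, so it is the strongest binder of the set. Compound 4 `O=C(O)CCCc1ccccc1-c1cccc(-c2ccccc2OCc2ccccc2)c1` has not yet been measured. It differs from compound 3 in one place: 3-carboxypropyl in place of 2-carboxyethenyl on an aromatic carbon. Among the measured compounds shown here, no measured pair shows a change of this kind, so its effect is uncertain. Compound 1 gives a higher number than compound 3, but it differs from compound 3 in more than one place and offers no clean guide. Compound 4 is expected to give 1800 nM, within a range from 600 nM to 5500 nM. The expected step of a 2.2-fold higher number from compound 3 to compound 4 (0.34 log units; beyond the scatter) is a modest weakening, close to the edge of the scatter.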

Compound 4, inhibition constant: 3500 nM
For compound 4 the middle estimate is 1.9-fold (0.29 log units) below the measured one; measured number inside the range.
By their numbers in this assay, from the lowest: compound 3; then compounds 1 and 4 (each within the scatter of the next); then compound 2.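

In this assay, among the compounds shown here, this is the first clean one-place comparison, and replacing 2-carboxyethenyl with 3-carboxypropyl on this aromatic carbon, ortho to a large group, brings a modest weakening (a 4.2-fold higher number from compound 3 to compound 4 (0.62 log units; beyond the scatter)). The position therefore does not treat these two acid-bearing chains alike: the longer one, with one double bond rather than two, gives the weaker binder. Nothing available explains the loss.

For the compounds shown here, the single step cannot separate the added carbon from the lost double bond. From the compounds shown here alone, how a shorter carboxymethyl chain, or an amide in place of the carboxylic acid, would behave here also remains open.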